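Aryl ether series: extending the phenoxy arm of compound 3

The source may hold more compounds than are shown below. What is called first, only, known or untested is meant among the compounds shown, and "the series" means these compounds.

Compound 3 `COc1cc2c(cc1OC)CN(S(=O)(=O)c1ccc(-n3cc(CO)nn3)cc1)CC2` gives 72000 nM in a functional assay on HuCC-A1 cells (Homo sapiens) for cytotoxicity, read by MTT assay, with a stated time of 48 h (a lower number here means a stronger inhibitor, a higher number a weaker inhibitor), the highest number of the three measured; compound 1 `COc1cc2c(cc1OC)CN(S(=O)(=O)c1ccc(-n3cc(COc4ccc(C=O)cc4)nn3)cc1)CC2` gives 31100 nM and compound 2 `COc1cc2c(cc1OC)CN(S(=O)(=O)c1ccc(-n3cc(COc4ccccc4C)nn3)cc1)CC2` gives 39700 nM. Compound 4 `COc1cc2c(cc1OC)CN(S(=O)(=O)c1ccc(-n3cc(COc4ccc(C=O)cc4OC)nn3)cc1)CC2` differs from compound 3 by 4-formyl-2-methoxyphenyl in place of hydrogen on an oxygen on a saturated carbon. Within the data shown here, the steps that bear on this run in the opposite direction: a 2.3-fold higher number from compound 1 to compound 3 (0.36 log units; beyond the scatter) and a 1.8-fold higher number from compound 2 to compound 3 (0.26 log units; within the scatter). Replacing the hydrogen on this oxygen with an aryl group has thus given a lower number in both cases, once beyond the scatter. For compound 4 the step of a 2.4-fold lower number from compound 3 to compound 4 (0.38 log units; beyond the scatter) is expected. The entering group shares the formyl of compound 1, whose value in this assay was 31100 nM. Compound 4 is therefore estimated at 30000 nM, within 14000 nM to 65000 nM.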

Compound 4, half-maximal inhibitory concentration: 40000 nM
For compound 4 the middle estimate is 1.3-fold (0.12 log units) below the measured one; low and high end bracket the measured number.
By their numbers in this assay, from the lowest: compounds 1, 2, 4 and 3 (each within the scatter of the next, the first and the last beyond it).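

In this assay the step from the free hydroxy to the 4-formyl-2-methoxyphenoxy group (a 1.8-fold lower number from compound 3 to compound 4 (0.26 log units; within the scatter)) stays within the scatter, unlike the step that links compound 1 to compound 3. Methoxy in place of hydrogen on an aromatic carbon (a 1.3-fold higher number from compound 1 to compound 4 (0.11 log units; within the scatter)) and the exchange of 2-methylphenyl for 4-formyl-2-methoxyphenyl (a 1.0-fold higher number from compound 2 to compound 4 (0.00 log units; within the scatter)) both leave the number within the scatter. Nothing on hand accounts for these steps.

Open, going by these compounds, is whether an amine or a carboxylic acid in place of the formyl would give a step beyond the scatter. Also open, on these data alone, is whether any aryl group on this oxygen gives a number far below that of compound 1.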